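Cyano in place of chloro on the nitrile-bearing phenyl ring

A few compounds are considered here, and "the series" means these few. Any claim that something is new, unique, unknown or untested is made for them only; others in the source may bear on it.

In a functional assay on CHO cells for inhibition of metabotropic glutamate receptor 5 (Rattus norvegicus), read by FLIPR and calcium flux (on this read-out higher numbers stand for weaker inhibition and lower numbers for stronger inhibition), compound 1 `Cc1ccc2ccc(-c3cccc(C#N)c3)cc2n1` gives 7.7 nM. Compound 2 `Cc1ccc2ccc(-c3cc(F)cc(C#N)c3)cc2n1` gives 0.8 nM, and compound 3 `Cc1ccc2ccc(-c3cc(Cl)cc(C#N)c3)cc2n1` gives 1.4 nM; compound 3 thus carries the second highest of the three numbers, separated from compound 2 by a gap within the scatter and from compound 1 by one beyond it. Compound 4 `Cc1ccc2ccc(-c3cc(C#N)cc(C#N)c3)cc2n1` differs from compound 3 by cyano in place of chloro on an aromatic carbon. Among the compounds with values here, no measured step brings a cyano group into that place. Within the data shown here, the steps that bear on it are a 9.6-fold lower number from compound 1 to compound 2 (0.98 log units; beyond the scatter), a 5.5-fold lower number from compound 1 to compound 3 (0.74 log units; beyond the scatter) and a 1.8-fold higher number from compound 2 to compound 3 (0.24 log units; within the scatter): both halogens lower the number against hydrogen, and their exchange stays within the scatter. Without precedent for the cyano group, no step beyond the scatter is expected in this assay, and compound 4 is estimated at 2.5 nM, range 0.8 nM to 8 nM, a step of a 1.8-fold higher number from compound 3 to compound 4 (0.25 log units; within the scatter).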

Compound 4, half-maximal inhibitory concentration: 2 nM
Compound 4: the middle estimate sits 1.3-fold (0.10 log units) above what was measured, and the stated range covers the measured number.
By their numbers in this assay, from the lowest: compounds 2, 3 and 4 (each within the scatter of the next, the first and the last beyond it); then compound 1.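

In this assay, cyano at this place also lowers the number against hydrogen (a 3.9-fold lower number from compound 1 to compound 4 (0.59 log units; beyond the scatter)), so the effect seen with fluoro and chloro extends to a group of two heavy atoms. Cyano and chloro remain unseparated (a 1.4-fold higher number from compound 3 to compound 4 (0.15 log units; within the scatter)), whereas fluoro and cyano now part (a 2.5-fold higher number from compound 2 to compound 4 (0.40 log units; beyond the scatter)), the first difference beyond the scatter among the groups replacing hydrogen here. Nothing available explains these steps. On these data alone, whether an amine, a carboxylic acid or a methoxy group at this place would keep the number as low remains open.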